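From 4-cyanophenyl to 3-methylpyridin-4-yl on the shared core

A few compounds are considered here, and "the series" means these few. Any claim that something is new, unique, unknown or untested is made for them only; others in the source may bear on it.

In a functional assay on MCF7 cells (Homo sapiens) for cytotoxicity, read by CellTiter-Glo, with a stated time of 5 days (on this read-out higher numbers stand for weaker inhibition and lower numbers for stronger inhibition), compound 1 (`CC/C(=C(/c1ccc(/C=C/C(=O)O)nc1)c1ccc2[nH]ncc2c1)c1ccccc1`) gives 210 nM and compound 2 (`CC/C(=C(/c1ccc(/C=C/C(=O)O)cc1)c1ccc2[nH]ncc2c1)c1ccc(C#N)cc1`) gives 47 nM as the lower of the two numbers, a gap beyond the scatter. Compound 3 (`CC/C(=C(/c1ccc(/C=C/C(=O)O)cc1)c1ccc2[nH]ncc2c1)c1ccncc1C`) carries 3-methylpyridin-4-yl in place of 4-cyanophenyl on a double-bonded chain carbon bound to a double-bonded chain carbon and a saturated chain carbon. For the measured compounds named here, no measured pair isolates this change. In this assay a modest weakening is expected (a 1.9-fold higher number from compound 2 to compound 3 (0.28 log units; within the scatter)). Compound 3 is estimated at 90 nM with 30 nM to 280 nM as its expected range.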

Compound 3, half-maximal inhibitory concentration: 16 nM
Compound 3: the middle estimate sits 5.6-fold (0.75 log units) above what was measured; the whole stated range lies above it.
By their numbers in this assay, from the lowest: compound 3; then compound 2; then compound 1.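

In this assay, 3-methylpyridin-4-yl in place of 4-cyanophenyl gives a 2.9-fold lower number from compound 2 to compound 3 (0.47 log units; beyond the scatter). This place on the chain therefore does not depend on the nitrile, and a six-membered aromatic ring with one hetero atom serves better here than the all-carbon ring of compound 2. No measurement at hand accounts for this gain. The compounds shown leave open whether the step goes with the methyl or with the ring nitrogen. A plain pyridin-4-yl and a 2-methylphenyl at this place would separate the two.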